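Swapping a pyridine substituent and what it may do to lipophilicity

A few compounds are considered here, and "the series" means these few. Any claim that something is new, unique, unknown or untested is made for them only; others in the source may bear on it.

Compound 2 `Cc1cccc(Oc2ccc3nc(COc4cccc(C(=O)O)c4)n(C)c3c2)n1`: 0.8
Compound 1 `Cn1c(COc2cccc(C(=O)O)c2)nc2ccc(Oc3ccc(Cl)cn3)cc21`: 1.2

In a physicochemical assay for lipophilicity, read by LC-MS, in phosphate buffer, measured as octanol-water partition, with a stated time of 30 min, at pH 7.4, tested at 200 mM (on this read-out lower numbers stand for lower lipophilicity and higher numbers for higher lipophilicity), compound 2 gives 0.8, the lower of the two numbers, and compound 1 gives 1.2. Compound 3 `Cn1c(COc2cccc(C(=O)O)c2)nc2ccc(Oc3ccc(F)cn3)cc21` differs from compound 2 by 5-fluoropyridin-2-yl in place of 6-methylpyridin-2-yl on an oxygen on an aromatic ring. Going by the values given here, only the step of a number 0.40 log units lower from compound 1 to compound 2 (beyond the scatter) bears on this, and it ran the other way, from a chloro-bearing ring to the methyl-bearing one. The fluoro-bearing ring of compound 3 is expected to land close to compound 2, so a step of a number 0.10 log units lower from compound 2 to compound 3 (within the scatter) within the scatter is estimated. For compound 3 the value is expected near 0.7, between 0.3 and 1.1.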

Compound 3, distribution coefficient: 0.6
Estimate against measurement, compound 3: 0.10 log units above, and the stated range covers the measured number.
By their numbers in this assay, from the lowest: compounds 3 and 2 (each within the scatter of the next); then compound 1.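

Fluoro in place of chloro on an aromatic carbon gives a number 0.60 log units lower from compound 1 to compound 3 (beyond the scatter) in this assay, and this isolates a change of halogen alone on the ring attached through oxygen. By contrast, 5-fluoropyridin-2-yl in place of 6-methylpyridin-2-yl gives a number 0.20 log units lower from compound 2 to compound 3 (within the scatter) and so does not separate these two groups on this read-out. Nothing available explains either step.

On these data alone, how a methoxy group or an amine in place of the fluoro would read in this assay remains open. So does whether a bromo group would extend the difference seen between the two halogens.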